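This account rests on a few compounds, and the source may have more. Where it says the series, first, only, none or still open, it means among the compounds named here.

The measured compounds:

Compound 1, `COC1Cc2c(cnn2-c2ccccc2)C2(CCN(CCCc3ccccc3)CC2)O1`, gives 3.2 nM in an assay for displacement of a labelled ligand from Sigma non-opioid intracellular receptor 1 (Cavia porcellus), read by scintillation counting, with a stated time of 180 min; on this read-out lower numbers stand for stronger inhibition and higher numbers for weaker inhibition.
Compound 2, `CCCN1CCC2(CC1)OC(OC)Cc1c2cnn1-c1ccccc1`, gives 33 nM in this assay.
Compound 3, `COC1Cc2c(cnn2C)C2(CCN(CCCc3ccccc3)CC2)O1`, gives 93 nM in this assay.

Compound 4, `CCCN1CCC2(CC1)OC(OC)Cc1c2cnn1C`, has not yet been measured. It differs from compound 3 by hydrogen in place of phenyl on a saturated chain carbon, three bonds along the chain from an amine nitrogen in a ring. This same change has already been made once among the measured compounds: compound 2 differs from compound 1 by hydrogen in place of phenyl on a saturated chain carbon, three bonds along the chain from an amine nitrogen in a ring, and that step gave a 10-fold higher number from compound 1 to compound 2 (1.01 log units; beyond the scatter). The two cores on which the change is made are not identical; compound 3 differs from compound 1 by methyl in place of phenyl on an aromatic nitrogen, a change that on its own gave a 29-fold higher number from compound 1 to compound 3 (1.46 log units; beyond the scatter). Compound 3 thus stands highest of the three numbers. Whether the same change on this second core gives a step of the same size is not known, but the place of the change is the same. For compound 4 a step of a 9.7-fold higher number from compound 3 to compound 4 (0.99 log units; beyond the scatter) is expected in this assay. This expectation rests on the earlier pair, where compound 1 to compound 2 gave a 10-fold higher number from compound 1 to compound 2 (1.01 log units; beyond the scatter). Compound 4 is therefore estimated at 900 nM, with a likely range from 300 nM to 3000 nM.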

Compound 4, inhibition constant: > 1000 nM
Compound 4: only a limit was reported (the forecaster's own chance of this, stated with the estimate: 10%); middle value at least 1.1-fold (0.04 log units) from the limit.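

In this assay, compound 4 is reported as > 1000 nM, which is a limit of the assay and not an exact number. Hydrogen in place of phenyl on the chain gives an at least 10-fold higher number from compound 3 to compound 4 (1.03 log units; beyond the scatter), so the number rises on both cores, but the size of the step on the second core remains unsettled: the same change on two cores in this assay, a 10-fold higher number (1.01 log units; beyond the scatter) from compound 1 to compound 2 and an at least 10-fold higher number (1.03 log units; beyond the scatter) from compound 3 to compound 4; the limit leaves it open whether they differ. Methyl in place of phenyl on the aromatic nitrogen gives an at least 30-fold higher number from compound 2 to compound 4 (1.48 log units; beyond the scatter), again a rise in the same direction whose true size cannot be fixed: the same change on two cores in this assay, a 29-fold higher number (1.46 log units; beyond the scatter) from compound 1 to compound 3 and an at least 30-fold higher number (1.48 log units; beyond the scatter) from compound 2 to compound 4; the limit leaves it open whether they differ.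

The compounds shown carry only phenyl or hydrogen on the chain and only phenyl or methyl on the aromatic nitrogen, and so they do not show how much of each step comes from the whole phenyl ring. Going by these compounds, how a longer chain carrying the phenyl, or a benzyl group on the aromatic nitrogen, would read in this assay remains open.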